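A few compounds are considered here, and "the series" means these few. Any claim that something is new, unique, unknown or untested is made for them only; others in the source may bear on it.

Compound 1 `O=S(=O)(CC1=NCCS1)C1C(c2ccccc2)=NOC1c1ccccc1` gives "not active" (no number reported) in a functional assay, tested at 100 ug/mL; on this read-out lower numbers stand for a weaker effect and higher numbers for a stronger effect at the one concentration tested. Compound 2 `Cc1ccc(C2CNN=C2S(=O)(=O)CC2=NCCS2)cc1` gives 45.1% in this assay. Compound 3 `Cc1ccc(C2CNN=C2S(=O)(=O)CC2=NCCO2)cc1` gives 46.8% in this assay.

Compound 2 and compound 3 differ in one place only: a group of 5 heavy atoms (3 carbon, 1 nitrogen, 1 oxygen; one five-membered non-aromatic ring with 2 hetero atoms) in place of a group of 5 heavy atoms (3 carbon, 1 nitrogen, 1 sulfur; one five-membered non-aromatic ring with 2 hetero atoms), on a saturated chain carbon bound to a sulfonyl sulfur. That change made a step of a number 1.7 percentage points higher from compound 2 to compound 3 (within the scatter). The cores of compound 1 and compound 2 differ in more than one place, and this difference is not broken down here.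

Compound 4 `O=S(=O)(CC1=NCCO1)C1C(c2ccccc2)=NOC1c1ccccc1` is not yet measured. Among the compounds with values here, it differs from compound 1 by a group of 5 heavy atoms (3 carbon, 1 nitrogen, 1 oxygen; one five-membered non-aromatic ring with 2 hetero atoms) in place of a group of 5 heavy atoms (3 carbon, 1 nitrogen, 1 sulfur; one five-membered non-aromatic ring with 2 hetero atoms), on a saturated chain carbon bound to a sulfonyl sulfur, the same change as the one from compound 2 to compound 3. Since that earlier step lay within the scatter, a step of similar small size is expected from compound 1 to compound 4 in this assay. Because compound 1 gave "not active" (no number reported), compound 4 is expected to show little effect, estimated at 10%, between 0% and 30%.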

Compound 4, a percentage reported as activity, at one concentration (the size of the read-out at that concentration, not a potency): 56.6%
Compound 4: middle estimate off by 46.6 percentage points, on the low side, and the stated range ends below it.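

Within the data shown here, compound 1 has no number in this assay, and no step from it to compound 4 can be read. The compounds shown leave open how large this ring change is on the core of compound 1. No measurement shown bears on the reason for the result.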